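The source may hold more compounds than are shown below. What is called first, only, known or untested is meant among the compounds shown, and "the series" means these compounds.

Measured so far:
Compound 1, `COc1ccccc1NC(=O)COc1cc(C)nc2ccc(C(F)(F)F)cc12`, in an ADME assay on HepG2 cells (Homo sapiens) for cytotoxicity, read by trypan blue exclusion, with a stated time of 48 h, in the presence of a further agent that is not named here (a higher number here means that more compound is tolerated, a lower number that less compound is tolerated), compound 1 gives > 128000 nM, which is a limit of the assay and not a number.
Compound 2, `COc1ccc2nc(C)cc(OCC(=O)Nc3ccccc3Cl)c2c1`, in this assay compound 2 gives > 140000 nM, again a limit of the assay rather than a number.

Going by the values given here, compound 2 therefore stands only at a limit, as does the other measured compound (the limit of > 128000 nM in this assay, at which 1 of the 2 values shown sits, (the limit of > 140000 nM in this assay, at which 1 of the 2 values shown sits)), and no step between measured compounds is known. Compound 3, `CCCCCNC(=O)COc1cc(C)nc2ccc(OC)cc12`, differs from compound 2 by pentyl in place of 2-chlorophenyl on an amide-type nitrogen. With only limits available, the expected step in this assay is none beyond the scatter. Compound 3 is expected near 140000 nM, in a range from 50000 nM to 300000 nM. The expected step is a number no higher from compound 2 to compound 3 (the limit leaves the size open).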

Compound 3, half-maximal cytotoxic concentration: 106000 nM
Compound 3: middle estimate off by 1.3-fold (0.12 log units), on the high side; measured number inside the range.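

In this assay compound 3 gives 106000 nM, the only true number among the compounds shown, so a pentyl chain on the amide-type nitrogen gives a measurable reading. Replacing 2-chlorophenyl with pentyl gives an at least 1.3-fold lower number from compound 2 to compound 3 (0.12 log units; that floor lies within the scatter), which neither shows nor rules out a real change. The true size of the step stays open because the value of compound 2 is a limit of the assay and not a number: the limit of > 140000 nM in this assay, at which 1 of the 3 values shown sits.

On these data alone, whether a longer chain such as octyl, or a pentyl chain ending in an amine, would give a different number remains open.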